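Compound 3 and Its Untested Mirror Image

The source may report more compounds than this note shows. Statements on the series, on what has been measured and on what is new or still open speak of the compounds shown alone.

Of the compounds shown here, three built on a shared core have been measured in a functional assay on HCT-116 cells (Homo sapiens) for inhibition, read by MTT assay, with a stated time of 72 h; a higher number here means a weaker inhibitor, a lower number a stronger inhibitor: compound 1 (`CC1=NN(c2ccccc2)C(=O)[C@]12C(=O)C=CC[C@H]2c1ccc(C)cc1`) gives 4220 nM, compound 2 (`CC1=NN(c2ccccc2)C(=O)[C@@]12C(=O)C=CC[C@@H]2c1cccc(C)c1`) gives 3800 nM, and compound 3 (`CC1=NN(c2ccc(C)cc2)C(=O)[C@]12C(=O)C=CC[C@H]2c1ccc(C)cc1`) gives 3530 nM. These values lie within the scatter of one another, so compound 3 stands level with the other two.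

Compound 4 (`CC1=NN(c2ccc(C)cc2)C(=O)[C@@]12C(=O)C=CC[C@@H]2c1ccc(C)cc1`) comes from compound 3 through (the two compounds have the same atoms and bonds and differ only in configuration as drawn: 2 of 2 stereo elements differ (all stereocentres are inverted: mirror images); a stereocentre at a saturated ring carbon is drawn S in compound 3 and R in compound 4; a stereocentre at a saturated ring carbon is drawn S in compound 3 and R in compound 4). The two are mirror images, with the same atoms and bonds. For the measured compounds named here, the only measured step, a 1.2-fold lower number from compound 1 to compound 3 (0.08 log units; within the scatter), put methyl in place of hydrogen on an aromatic carbon and stayed within the scatter. Going by the values given here, it is a different kind of change, and no pair of mirror images has been measured here, so the data give no direct guide. With nothing pointing either way, no step beyond the scatter is expected in this assay, although this expectation is uncertain. The estimated step is a 1.1-fold higher number from compound 3 to compound 4 (0.03 log units; within the scatter). For compound 4 the expected value is 3800 nM, with an estimated range from 1800 nM to 8000 nM.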

Compound 4, half-maximal inhibitory concentration: 4150 nM
Compound 4: the middle estimate sits 1.1-fold (0.04 log units) below what was measured; the range from low to high includes it.
By their numbers in this assay, from the lowest: compounds 3, 2, 4 and 1 (each within the scatter of the next).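

For the compounds shown here, this is the first pair of mirror images, and in this assay the two stand level: a 1.2-fold higher number from compound 3 to compound 4 (0.07 log units; within the scatter). For this pair, then, the configuration as drawn produces no difference that can be told apart from the scatter. The comparison is a clean one because nothing else separates the two structures: the fact that compounds 3 and 4 differ only in the configuration as drawn.

The compounds shown include no case with one stereocentre inverted alone, and no other pair of mirror images, so it stays open whether this result holds beyond compound 3 and compound 4. Also open is how this assay would respond to an amine or a carboxylic acid on an aromatic ring, where the compounds shown carry only methyl or hydrogen.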